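Nitrate ester side chain: removing the chain methyl

The source may report more compounds than this note shows. Statements on the series, on what has been measured and on what is new or still open speak of the compounds shown alone.

Measured so far in a functional assay (cardiac atrium) for agonist activity, with Cavia porcellus as the target; a higher number here means that more compound is needed for the effect, a lower number that less compound is needed:
- compound 1, `CC1=C(C(=O)O[C@H](C)CO[N+](=O)[O-])[C@H](c2cccc3nonc23)C([N+](=O)[O-])=C(C)C1`, gives 1920 nM
- compound 2, `CC1=C(C(=O)O[C@@H](C)CO[N+](=O)[O-])[C@H](c2cccc3nonc23)C([N+](=O)[O-])=C(C)C1`, gives 156 nM

Compound 2 stands lowest of the two numbers in this assay; its nearest neighbour is compound 1, reached by a 12-fold lower number from compound 1 to compound 2 (1.09 log units; beyond the scatter), a large step. The only thing that separates these two is the fact that compounds 1 and 2 differ only in the configuration as drawn, so the configuration at the saturated chain carbon alone accounts for the gap between compound 1 and compound 2.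

Compound 3, `CC1=C(C(=O)OCCO[N+](=O)[O-])[C@H](c2cccc3nonc23)C([N+](=O)[O-])=C(C)C1`, has not been measured in this assay. Compared with compound 2 the change is hydrogen in place of methyl on a saturated chain carbon bound to an oxygen next to a carbonyl group and a saturated chain carbon. The stereocentre is thereby removed altogether, and neither measured compound is a direct precedent for this change. Within the data shown here, the one measured step shows that the substitution pattern at this carbon matters strongly; a chain with no methyl there is expected to fall somewhere between the two measured numbers rather than below compound 2. For compound 3 the estimate is 500 nM, within 150 nM to 1800 nM, meaning an expected step of a 3.2-fold higher number from compound 2 to compound 3 (0.51 log units; beyond the scatter).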

Compound 3, half-maximal effective concentration: 3130 nM
Estimate against measurement, compound 3: 6.3-fold (0.80 log units) below; measured number above the stated range.
By their numbers in this assay, from the lowest: compound 2; then compounds 1 and 3 (each within the scatter of the next).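

In this assay hydrogen in place of methyl on this saturated chain carbon gives a 20-fold higher number from compound 2 to compound 3 (1.30 log units; beyond the scatter) when the methyl is drawn S, whereas the same change from the methyl drawn R gives a 1.6-fold higher number from compound 1 to compound 3 (0.21 log units; within the scatter) and stays within the scatter. The methyl as such therefore does not set the low number: compound 1, with its methyl drawn R, cannot be told apart from compound 3, which has no methyl at all, and only the S-drawn methyl of compound 2 stands apart. The earlier pair could not separate a gain from the S-drawn methyl from a loss caused by the R-drawn one, and compound 3 now places the chain without a methyl level with the R-drawn compound, so the step rests on this one configuration: the fact that compounds 1 and 2 differ only in the configuration as drawn.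

Going by these compounds, whether an ethyl drawn S at this carbon would hold the low number of compound 2 remains open. Also open, on these data alone, is whether a longer chain carrying the nitrate ester would keep the same dependence on configuration.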